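This account rests on a few compounds, and the source may have more. Where it says the series, first, only, none or still open, it means among the compounds named here.

In a functional assay on Huh-7 cells (Homo sapiens) for inhibition, read by MTT assay, with a stated time of 48 h (on this read-out lower numbers stand for stronger inhibition and higher numbers for weaker inhibition), compound 1 `COc1ccc2c(=O)c(/C=C/C(=O)Nc3cccc(Cl)c3)coc2c1` gives > 100000 nM, which is a limit of the assay and not a number. Compound 2 `COc1ccc2c(=O)c(/C=C/C(=O)NCc3ccccc3)coc2c1` gives 13600 nM and compound 3 `COc1ccc2c(=O)c(/C=C/C(=O)NCc3ccccc3F)coc2c1` gives 8450 nM. Going by the values given here, that gap, a 1.6-fold lower number from compound 2 to compound 3 (0.21 log units; within the scatter), is within the scatter, and these two are the only numbers at hand. Compound 4 `COc1ccc(NC(=O)/C=C/c2coc3cc(OC)ccc3c2=O)cc1` has 4-methoxyphenyl in place of benzyl on an amide-type nitrogen. Compound 1 carries 3-chlorophenyl on that nitrogen, and both an at least 7.3-fold lower number from compound 1 to compound 2 (0.86 log units; beyond the scatter) and an at least 11-fold lower number from compound 1 to compound 3 (1.07 log units; beyond the scatter) run opposite to this change, so a clearly higher number is expected in this assay. The expected size is a 3.7-fold higher number from compound 2 to compound 4 (0.57 log units; beyond the scatter). For compound 4 the estimated value is 50000 nM, with an expected range of 15000 nM to 100000 nM.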

Compound 4, half-maximal inhibitory concentration: > 100000 nM
Compound 4: no number, only a limit (the forecaster's own chance of this, stated with the estimate: 45%); at least 2.0-fold (0.30 log units) between middle value and limit.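

Replacing benzyl with 4-methoxyphenyl on the amide-type nitrogen gives an at least 7.3-fold higher number from compound 2 to compound 4 (0.86 log units; beyond the scatter), and replacing 2-fluorobenzyl with it gives an at least 11-fold higher number from compound 3 to compound 4 (1.07 log units; beyond the scatter). Among the compounds shown, the loss of a measurable number no longer rests on 3-chlorophenyl alone, as compound 1 and compound 4, each with a substituted phenyl on that nitrogen, stand at a limit of the assay: the limit of > 100000 nM in this assay, at which 2 of the 4 values shown sit. The step from compound 1 to compound 4 cannot be read, since both values are limits.

Going by these compounds, whether unsubstituted phenyl or a longer chain such as 2-phenylethyl on that nitrogen gives a number in this assay remains open. So does how far compound 1 and compound 4 lie past the limit.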